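The source may hold more compounds than are shown below. What is called first, only, known or untested is meant among the compounds shown, and "the series" means these compounds.

Measured in a functional assay on Raji cells (Homo sapiens) for cytotoxicity, with a stated time of 72 h; on this read-out lower numbers stand for an effect already at smaller amounts and higher numbers for an effect only at larger amounts of compound:
Compound 1 `C=C[C@@](C)(/C=C/c1ccc(O)c(/C=C/C(=O)OCc2ccccc2)c1)CCC=C(C)C`: > 26000 nM (a limit)
Compound 2 `C=C[C@@](C)(/C=C/c1ccc(O)c(/C=C(\C)C(=O)OCC)c1)CCC=C(C)C`: > 26000 nM (a limit)

Compound 2 has no number on this read-out, only the limit > 26000 nM. Neither measured compound gives more: the limit of > 26000 nM in this assay, at which 2 of the 2 values shown sit. Compound 3 `C=C[C@@](C)(/C=C/c1ccc(O)c(/C=C/c2ccc(F)cc2)c1)CCC=C(C)C` carries 2-(4-fluorophenyl)ethenyl in place of 2-(ethoxycarbonyl)prop-1-en-1-yl on an aromatic carbon, ortho to a hydroxy group (2-(4-fluorophenyl)ethenyl in place of 2-(ethoxycarbonyl)prop-1-en-1-yl on an aromatic carbon). Among the measured compounds shown here, no measured step exists to guide the expectation, so only a small move toward lower numbers is expected, and the assay may again report only a limit. The expected step is an at least 1.3-fold lower number from compound 2 to compound 3 (0.11 log units; that floor lies within the scatter). Compound 3 is estimated at 20000 nM, with an expected range of 7000 nM to 40000 nM.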

Compound 3, half-maximal effective concentration: > 26000 nM
Compound 3: a limit, no number (the forecaster's own chance of this, stated with the estimate: 55%); middle value at least 1.3-fold (0.11 log units) away from the limit.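

In this assay compound 3 also gives only a limit, > 26000 nM. The steps from compound 1 and from compound 2 to compound 3 therefore cannot be read. How the three compounds rank on this read-out stays open: the limit of > 26000 nM in this assay, at which 3 of the 3 values shown sit.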